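A few compounds are considered here, and "the series" means these few. Any claim that something is new, unique, unknown or untested is made for them only; others in the source may bear on it.

Within the data shown here, compound 1, `CCCCCCCCCCCCCCNC(=O)[C@H](CO)/N=C/c1cccc([N+](=O)[O-])c1`, gives 104000 nM in a functional assay on cells (Homo sapiens) for cytotoxicity, read by MTT assay, with a stated time of 24 h (a higher number here means a weaker inhibitor, a lower number a stronger inhibitor), the highest of the three numbers measured so far. Compound 2, `CCCCCCCCCCCCCCNC(=O)[C@H](CO)/N=C/c1cccc(O)c1`, gives 32600 nM in this assay, and compound 3, `CCCCCCCCCCCCCCNC(=O)[C@H](CO)/N=C/c1ccccc1Cl`, gives 10300 nM. The steps between them are all beyond the scatter: a 3.2-fold lower number from compound 1 to compound 2 (0.50 log units; beyond the scatter), a 10-fold lower number from compound 1 to compound 3 (1.00 log units; beyond the scatter) and a 3.2-fold lower number from compound 2 to compound 3 (0.50 log units; beyond the scatter).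

Compound 4, `CCCCCCCCCCCCCCNC(=O)[C@H](CO)/N=C/c1cccc(OC)c1`, has not yet been measured. It differs from compound 1 by methoxy in place of nitro on an aromatic carbon. Among the measured compounds shown here, the one measured step that changes the same group, a 3.2-fold lower number from compound 1 to compound 2 (0.50 log units; beyond the scatter), lowered the number modestly, and the step of a 10-fold lower number from compound 1 to compound 3 (1.00 log units; beyond the scatter) shows that replacing the 3-nitrophenyl altogether also lowered it. For the measured compounds named here, no measured pair shows a methoxy in place of nitro directly, so the expectation rests on these two steps. Compound 4 is therefore expected to give a lower number than compound 1, with the step of a 3.0-fold lower number from compound 1 to compound 4 (0.47 log units; beyond the scatter) expected to be modest. The estimate for compound 4 in this assay is 35000 nM, within a range of 15000 nM to 80000 nM.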

Compound 4, half-maximal inhibitory concentration: 31300 nM
Compound 4: the middle estimate sits 1.1-fold (0.05 log units) above what was measured, within the range that was stated.
By their numbers in this assay, from the lowest: compound 3; then compounds 4 and 2 (each within the scatter of the next); then compound 1.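

In this assay, the direct replacement of nitro by methoxy on this aromatic carbon gives a 3.3-fold lower number from compound 1 to compound 4 (0.52 log units; beyond the scatter), so hydroxy is no longer the only group shown to differ from nitro here. Placing methyl on the oxygen makes no readable difference, with a 1.0-fold lower number from compound 2 to compound 4 (0.02 log units; within the scatter), so the hydrogen on that oxygen is not required for a number at this level. The 3-methoxyphenyl compound still stands apart from the 2-chlorophenyl compound, with a 3.0-fold higher number from compound 3 to compound 4 (0.48 log units; beyond the scatter), so methoxy does not close that gap.

Going by these compounds, whether an amine or an ethoxy group on this aromatic carbon would stay level with hydroxy and methoxy remains open, as does whether the number of compound 3 follows from the chlorine or from where it sits. Nothing given here accounts for these differences.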